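A few compounds are considered here, and "the series" means these few. Any claim that something is new, unique, unknown or untested is made for them only; others in the source may bear on it.

Compound 1, `COc1cc[nH]c1/C=C1/C(=O)Nc2ccc(F)cc21`. In a functional assay on MDA-MB-435 cells (Homo sapiens) for inhibition (a higher number here means a weaker inhibitor, a lower number a stronger inhibitor), compound 1 gives > 30000 nM, which is a limit of the assay rather than a number.
Compound 2, `COc1cc[nH]c1/C=C1\C(=O)Nc2ccc(F)c(I)c21`. In this assay compound 2 gives > 30000 nM, again a limit.
Compound 3, `COc1cc[nH]c1/C=C1\C(=O)Nc2ccc(F)c(C#C[C@@H](N)CO)c21`. In this assay compound 3 gives 300 nM.

Within the data shown here, compound 3 thus holds the only measured number of the three; the other two values sit at the limit of > 30000 nM in this assay, at which 2 of the 3 values shown sit. Compound 4, `COc1cc[nH]c1/C=C1\C(=O)Nc2ccc(F)c(C#C[C@@H](NS(C)(=O)=O)[C@@H](C)O)c21`, differs from compound 3 in one place: 2-hydroxy-1-(methanesulfonamido)propyl in place of 1-amino-2-hydroxyethyl on a triple-bonded carbon. Among the measured compounds shown here, the single measured step, an at least 100-fold lower number from compound 2 to compound 3 (2.00 log units; beyond the scatter), replaced iodo with the whole amino-alcohol chain and does not speak to capping that chain's amine with a methanesulfonyl group and adding a methyl. For the measured compounds named here, with no measured step covering this change, the expected step in this assay is none beyond the scatter, a 1.3-fold higher number from compound 3 to compound 4 (0.12 log units; within the scatter). Compound 4 is therefore estimated at 400 nM, within a range of 100 nM to 1500 nM.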

Compound 4, half-maximal inhibitory concentration: 2630 nM
The estimate for compound 4 lay 6.6-fold (0.82 log units) below the measured number; the whole stated range lies below it.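

Changes within the chain on the triple-bonded carbon clearly matter: putting 2-hydroxy-1-(methanesulfonamido)propyl in place of 1-amino-2-hydroxyethyl gives an 8.8-fold higher number from compound 3 to compound 4 (0.94 log units; beyond the scatter). The earlier step showed only what the whole chain did in place of iodo, whereas this one shows that the free amine form, compound 3, is the stronger of the two. Compound 4 still gives a measured number rather than sitting at the limit: the limit of > 30000 nM in this assay, at which 2 of the 4 values shown sit.

This change adds a methanesulfonyl group and a methyl together, so the step cannot be split between them. From the compounds shown here alone, an acetamide at that nitrogen, or the free amine with the added methyl alone, remains open.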